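The source may report more compounds than this note shows. Statements on the series, on what has been measured and on what is new or still open speak of the compounds shown alone.

Of the compounds shown here, two built on a shared core have been measured in an assay on LtK cells with ATP-sensitive inward rectifier potassium channel 11 (Homo sapiens) as the target; a higher number here means that more compound is needed for the effect, a lower number that less compound is needed. Compound 1 `CCC(=O)Nc1c(C(O)(C(F)(F)F)C(F)(F)F)ccc2ccccc12` gives 15 nM in this assay. Within the data shown here, compound 2 `O=C(CC1CCCC1)Nc1c(C(O)(C(F)(F)F)C(F)(F)F)ccc2ccccc12` gives 81 nM in this assay, which is the highest of the two numbers, and the only step seen so far, a 5.4-fold higher number from compound 1 to compound 2 (0.73 log units; beyond the scatter), shows that enlarging the chain on the amide raised the number.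

Compound 3 `N#Cc1cccc(C(=O)Nc2c(C(O)(C(F)(F)F)C(F)(F)F)ccc3ccccc23)c1` is the next compound, not yet measured in this assay. It differs from compound 2 in one place: 3-cyanophenyl in place of cyclopentylmethyl on a carbonyl carbon. Among the measured compounds shown here, the one measured step that bears on this change, a 5.4-fold higher number from compound 1 to compound 2 (0.73 log units; beyond the scatter), tells only that a bulkier saturated group gave a modestly higher number; there is no measured step in which an aromatic group replaces a saturated one on this carbonyl carbon, so the direction is uncertain. A step of moderate size in either direction, or none beyond the scatter, is plausible. On that basis compound 3 is expected to give 50 nM in this assay, with a range from 10 nM to 250 nM, which means an estimated step of a 1.6-fold lower number from compound 2 to compound 3 (0.21 log units; within the scatter).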

Compound 3, half-maximal effective concentration: 12 nM
For compound 3 the middle estimate is 4.2-fold (0.62 log units) above the measured one; measured number inside the range.
By their numbers in this assay, from the lowest: compounds 3 and 1 (each within the scatter of the next); then compound 2.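

In this assay this carbonyl carbon tolerates an aromatic group as well as a saturated chain: 3-cyanophenyl in place of cyclopentylmethyl gives a 6.8-fold lower number from compound 2 to compound 3 (0.83 log units; beyond the scatter) and so reverses the rise seen when the chain was enlarged. Set against the small ethyl group of compound 1, the same aromatic group gives a 1.3-fold lower number from compound 1 to compound 3 (0.10 log units; within the scatter) and so shows no change that can be told from the scatter. Heavy-atom count alone therefore does not track the number at this position, since 3-cyanophenyl has more heavy atoms than cyclopentylmethyl yet compound 3 has the lower number.

The compounds shown cannot separate the contribution of the aromatic ring from that of its nitrile, and a plain phenyl group would be needed to divide the two. A cyclohexyl group directly on the carbonyl carbon would likewise show whether the methylene link of cyclopentylmethyl or the saturated ring goes with the higher number of compound 2. No accompanying measurement offers an explanation for these differences.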